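This account rests on a few compounds, and the source may have more. Where it says the series, first, only, none or still open, it means among the compounds named here.

Compound 1 `CCCC[C@H](NC(=O)[C@@H](NC(=O)c1cccc(C(N)=O)c1)C(C)CC)C(=O)CO` gives 110 nM in an assay on isolated protein for binding affinity to cathepsin S (Homo sapiens) (on this read-out lower numbers stand for stronger inhibition and higher numbers for weaker inhibition), the lower of the two numbers in hand. Compound 2 `COCC(=O)[C@H](CCc1ccccc1)NC(=O)[C@H](CC(C)C)NC(=O)OCc1ccccc1` gives 1960 nM in this assay, a weaker result, and it differs from compound 1 in several places at once, so the two values alone tell nothing about any single change. Compound 3 `CCC(C)[C@H](NC(=O)c1cccc(C(N)=O)c1)C(=O)N[C@@H](CCc1ccccc1)C(=O)CO` takes the step (phenyl in place of ethyl on a saturated chain carbon, three bonds along the chain from an amide-type nitrogen and a carbonyl carbon). Among the compounds with values here, with no single-change pair to lean on, the expected step from compound 1 to compound 3 is a 1.8-fold higher number from compound 1 to compound 3 (0.26 log units; within the scatter), a shift at about the edge of the scatter toward weaker binding. Compound 3 is estimated at 200 nM, with a range from 50 nM to 800 nM.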

Compound 3, inhibition constant: 88 nM
Compound 3: the middle estimate sits 2.3-fold (0.36 log units) above what was measured; the range from low to high includes it.
By their numbers in this assay, from the lowest: compounds 3 and 1 (each within the scatter of the next); then compound 2.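

Replacing ethyl with phenyl on this saturated chain carbon gives, in this assay, a 1.3-fold lower number from compound 1 to compound 3 (0.10 log units; within the scatter), so this position accepts the six-membered aromatic ring with no difference that can be read beyond the scatter. Within the data shown here, this is the first single-change comparison, and it shows that the ethyl group is not required here for binding at this level. Nothing in hand explains why the two numbers stay so close.

As far as these compounds go, it remains open whether a saturated cyclohexyl ring, or a phenyl ring carrying an amine or a carboxylic acid, would be tolerated at this place. The same holds for a longer chain at this position.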